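From methyl to bromo on compound 2

The compounds below may be only part of what the source reports. "The series", "measured", "known", "first", "only" and "open" are said of these compounds alone.

In a functional assay on HL-60 cells (Homo sapiens) for antiproliferative activity, with a stated time of 72 h (a higher number here means a weaker inhibitor of growth, a lower number a stronger inhibitor of growth), compound 2 `C=C(C)C(=O)c1ccc(OC(C)C(=O)O)cc1C` gives > 60000 nM, which is a limit and not a number. Compound 3 `C=C(CC)C(=O)c1ccc(OC(C)C(=O)O)cc1C` gives > 60000 nM, also a limit. That places compound 2 at the limit of > 60000 nM in this assay, at which 2 of the 3 values shown sit. In this assay compound 1 `C=C(CCCC)C(=O)c1ccc(OC(C)C(=O)OC)c(C)c1C` gives an actual number, 5200 nM.

Compound 4 `C=C(C)C(=O)c1ccc(OC(C)C(=O)O)cc1Br` differs from compound 2 by bromo in place of methyl on an aromatic carbon. For the measured compounds named here, the only measured step is a step that the two limits leave unreadable from compound 2 to compound 3, so it offers no size to carry over. No step beyond the scatter is expected in this assay, and another limit is the likely report. The expected change is a number no higher from compound 2 to compound 4 (the limit leaves the size open). Compound 4 is estimated at 60000 nM, within a range of 25000 nM to 120000 nM.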

Compound 4, concentration for 50% growth inhibition: > 60000 nM
Compound 4 gave a limit, no number; the forecaster's own chance of this, stated with the estimate: 80%; the middle value lies on the limit itself.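

For the compounds shown here, compound 4, like compound 2, gave a limit and not a number, so no step between them can be read: the limit of > 60000 nM in this assay, at which 3 of the 4 values shown sit. The compounds shown leave open whether bromo in place of methyl changes growth inhibition at all, and by how much.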